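A few compounds are considered here, and "the series" means these few. Any claim that something is new, unique, unknown or untested is made for them only; others in the source may bear on it.

The series rests on a shared sulfonamide-linked core, seen in compound 1 `O=S(=O)(NCCNCc1ccc(-c2ccccc2)cc1)c1cc(C(F)(F)F)cc(C(F)(F)F)c1`, compound 2 `O=S(=O)(NCCCNCc1ccc(Cl)c(C(F)(F)F)c1)c1cc(C(F)(F)F)cc(C(F)(F)F)c1` and compound 3 `CC(C)(C)c1ccc(CNCCNS(=O)(=O)c2cc(C(F)(F)F)cc(C(F)(F)F)c2)cc1`. Among the compounds with values here, in a functional assay on A2780 cells (Homo sapiens) for inhibition, read by MTT assay, with a stated time of 72 h (on this read-out higher numbers stand for weaker inhibition of growth and lower numbers for stronger inhibition of growth), compound 1 gives 2600 nM, and in this assay compound 3 gives 14000 nM; the only step measured within the set is a 5.4-fold higher number from compound 1 to compound 3 (0.73 log units; beyond the scatter). In this assay compound 2 gives 5900 nM, which places it second highest of the three numbers, nearer to compound 1 than to compound 3.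

Compound 4 `COc1cccc(CNCCCNS(=O)(=O)c2cc(C(F)(F)F)cc(C(F)(F)F)c2)c1` differs from compound 2 in one place: 3-methoxyphenyl in place of 4-chloro-3-(trifluoromethyl)phenyl on a saturated chain carbon bound to an amine nitrogen. Within the data shown here, no measured step changes the same groups. The step from compound 1 to compound 3 swaps a substituent on the same kind of aromatic ring, but with different groups, so it only loosely informs the present change and offers no clear direction. Compound 4 is therefore expected to sit close to compound 2, with a 1.2-fold higher number from compound 2 to compound 4 (0.07 log units; within the scatter) lying within the scatter. The estimate for compound 4 is 7000 nM, with a range from 2500 nM to 20000 nM.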

Compound 4, concentration for 50% growth inhibition: 1600 nM
Compound 4: the middle estimate sits 4.4-fold (0.64 log units) above what was measured; measured number below the stated range.
By their numbers in this assay, from the lowest: compounds 4 and 1 (each within the scatter of the next); then compound 2; then compound 3.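

On a saturated chain carbon bound to an amine nitrogen, the group carried is not interchangeable: in this assay, replacing 4-chloro-3-(trifluoromethyl)phenyl with 3-methoxyphenyl gives a 3.7-fold lower number from compound 2 to compound 4 (0.57 log units; beyond the scatter), which means stronger inhibition of growth. The entering group has fewer heavy atoms and one hydrogen-bond acceptor, where the leaving group has none, but this single step cannot separate those differences. No measured evidence accounts for the gain.

The compounds shown leave open whether the methoxy group itself carries the step or whether the loss of the chlorine and trifluoromethyl groups does. From the compounds shown here alone, it also remains open whether a hydroxyl group or a nitrile in place of the methoxy group would keep the lower number.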